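This account rests on a few compounds, and the source may have more. Where it says the series, first, only, none or still open, it means among the compounds named here.

Compound 1, `COc1ccc(/C=C/C(=O)c2ccc(NC(=O)CO[N+](=O)[O-])cc2)cc1`, in a functional assay on the whole organism (strain albino) for inhibition, with Rattus norvegicus as the target, read by paw edema, with stated times of 30 min and 4 h, at a dose of 100 mg/kg by the oral route (on this read-out lower numbers stand for less inhibition and higher numbers for more inhibition at the one dose given (going by the name of the read-out)), gives 51%.
Compound 2, `O=C(CO[N+](=O)[O-])Nc1ccc(C(=O)/C=C/c2ccco2)cc1`, in this assay gives 40%.
Compound 3, `COc1ccc(/C=C/C(=O)c2ccc(NC(=O)COc3ccc(/C(C)=N\O)cc3)cc2)cc1`, in this assay gives 42%.

The change from compound 1 to compound 2 is furan-2-yl in place of 4-methoxyphenyl on a double-bonded chain carbon bound to a double-bonded chain carbon, and with it the read-out moved by a number 11 percentage points lower from compound 1 to compound 2 (beyond the scatter). Compound 3 shares the left-hand part of compound 1 but its core differs from that of compound 1 by a group of 10 heavy atoms (8 carbon, 1 nitrogen, 1 oxygen; one six-membered aromatic ring of carbon only) in place of a group of 3 heavy atoms (1 nitrogen, 2 oxygen; no ring), on an oxygen on a saturated carbon; with that change the read-out moved by a number 9 percentage points lower from compound 1 to compound 3 (within the scatter). Compound 4, `C/C(=N/O)c1ccc(OCC(=O)Nc2ccc(C(=O)/C=C/c3ccco3)cc2)cc1`, is not yet measured. It differs from compound 3 by furan-2-yl in place of 4-methoxyphenyl on a double-bonded chain carbon bound to a double-bonded chain carbon, the same change that turned compound 1 into compound 2, made at the same place. For the measured compounds named here, for compound 4 a step of about a number 10 percentage points lower from compound 3 to compound 4 (within the scatter) is expected, resting on the single earlier step of a number 11 percentage points lower from compound 1 to compound 2 (beyond the scatter) seen on the other core, with the caution that one step on one core is a thin basis. Compound 4 is therefore estimated at 32%, with a range from 20% to 45%.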

Compound 4, a percentage reported as inhibition, in the whole organism at one dose (the size of the read-out at that dose, not a potency): 48%
The estimate for compound 4 lay 16 percentage points below the measured number, and the stated range ends below it.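

In this assay, furan-2-yl in place of 4-methoxyphenyl gives a number 6 percentage points higher from compound 3 to compound 4 (within the scatter), so this change does not carry over as a fixed step from the core of compound 1 to the core of compound 3: the same change on two cores in this assay, a number 11 percentage points lower (beyond the scatter) from compound 1 to compound 2 and a number 6 percentage points higher (within the scatter) from compound 3 to compound 4, 17 percentage points apart, beyond the scatter of two such steps. The swap of the two groups on the oxygen on a saturated carbon gives a number 8 percentage points higher from compound 2 to compound 4 (within the scatter) and likewise fails to repeat its earlier step: the same change on two cores in this assay, a number 9 percentage points lower (within the scatter) from compound 1 to compound 3 and a number 8 percentage points higher (within the scatter) from compound 2 to compound 4, 17 percentage points apart, beyond the scatter of two such steps. Among these four compounds, the step seen for either change depends on what the rest of the molecule carries, but with so few compounds, each tested at one dose, this does not show why the steps differ or what either change would do on a further core.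

The compounds shown leave open whether another ring in the same place, such as thiophene or pyridine, would behave like furan-2-yl or like 4-methoxyphenyl. They also leave open what a small group such as methyl would do on the oxygen on a saturated carbon.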